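The source may hold more compounds than are shown below. What is called first, only, known or untested is meant among the compounds shown, and "the series" means these compounds.

Measured compounds:
- compound 1 `CCNC(=O)NC1=CS(=O)(=O)O[C@@]12[C@@H](CO[Si](C)(C)C(C)(C)C)O[C@@H](n1cc(C)c(=O)n(C)c1=O)[C@@H]2O[Si](C)(C)C(C)(C)C`: >= 3200 nM
- compound 2 `COC(=O)CC(=O)NC1=CS(=O)(=O)O[C@@]12[C@@H](CO[Si](C)(C)C(C)(C)C)O[C@@H](n1cc(C)c(=O)n(C)c1=O)[C@@H]2O[Si](C)(C)C(C)(C)C`: 400000 nM
- compound 3 `Cc1cn([C@@H]2O[C@H](CO[Si](C)(C)C(C)(C)C)[C@@]3(OS(=O)(=O)C=C3NCC(=O)C(N)=O)[C@H]2O[Si](C)(C)C(C)(C)C)c(=O)n(C)c1=O`: >= 16000 nM

In a functional assay on HEL cells (Homo sapiens) for cytotoxicity, read by microscopy (on this read-out higher numbers stand for lower toxicity in this test and lower numbers for higher toxicity in this test), compound 1 stands only at a limit of the assay, namely >= 3200 nM, so no number is known for it. Compound 3 likewise sits at a limit, >= 16000 nM. Within the data shown here, compound 2 is the only one with a plain number. The shared core carries a substituent on an amine nitrogen, and the change studied here is (((azetidin-1-yl)carbonyl)carbonyl)methyl in place of ethylcarbamoyl on an amine nitrogen, giving compound 4 `Cc1cn([C@@H]2O[C@H](CO[Si](C)(C)C(C)(C)C)[C@@]3(OS(=O)(=O)C=C3NCC(=O)C(=O)N3CCC3)[C@H]2O[Si](C)(C)C(C)(C)C)c(=O)n(C)c1=O`.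

The measured step that most resembles this change is a step that the two limits leave unreadable from compound 1 to compound 3, which also replaces the ethylcarbamoyl group on the amine nitrogen; its size cannot be read because compound 1 sits at the limit of >= 3200 nM in this assay, at which 1 of the 3 values shown sits, and compound 3 at the limit of >= 16000 nM in this assay, at which 1 of the 3 values shown sits. The steps a step that the limit leaves unreadable from compound 1 to compound 2 and a step that the limit leaves unreadable from compound 2 to compound 3 are unreadable as well. No readable step therefore points in either direction, and toxicity in this range looks generally low. Compound 4 is expected around 30000 nM, in a range from 3200 nM to 400000 nM, which corresponds to an expected step that the limit leaves unreadable from compound 1 to compound 4, with a real chance that only a limit is reported.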

Compound 4, minimum cytotoxic concentration: 65000 nM
Compound 4: the middle estimate sits 2.2-fold (0.34 log units) below what was measured; the range from low to high includes it.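

Among these compounds, the first step on this amine nitrogen whose size can be read in this assay is a 6.2-fold lower number from compound 2 to compound 4 (0.79 log units; beyond the scatter) and it points towards higher toxicity in this test. So (((azetidin-1-yl)carbonyl)carbonyl)methyl in place of ((methoxycarbonyl)methyl)carbonyl is a change that moves the number by more than the usual scatter. The steps that start from compound 1 or compound 3 still cannot be read, which leaves azetidin-1-yl in place of amino on a carbonyl carbon without a size.

On these data alone, what a larger ring such as piperidin-1-yl, or a carboxylic acid, would do on that same carbonyl carbon remains open. With a single readable step resting on two plain numbers, no trend at this position can yet be drawn.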